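Ureido-pyrimidine anilides: methoxy to trifluoromethyl on the aniline ring

The source may hold more compounds than are shown below. What is called first, only, known or untested is meant among the compounds shown, and "the series" means these compounds.

Compound 1, `COc1ccc(OC)c(Nc2cc(NC(=O)Nc3c(Cl)cccc3Cl)ncn2)c1`, is the reference point of the series. Among the compounds with values here, in a functional assay on NCI-H226 cells (Homo sapiens) for inhibition, read by MTT assay, with a stated time of 48 h, tested at 10 uM (a higher number here means more inhibition at the concentration tested (going by the name of the read-out), a lower number less inhibition), compound 1 gives 81.7%, the highest of the three numbers so far, and its gaps to both other compounds lie beyond the usual scatter. Compound 2, `COc1cc(Br)ccc1Nc1cc(NC(=O)Nc2c(Cl)cccc2Cl)ncn1`, gives 43% in this assay, and compound 3, `CCc1cccc(Nc2cc(NC(=O)Nc3cc(OC)cc(OC)c3)ncn2)c1`, gives 36.7%. No pair among these three differs in a single place, so no step between measured compounds can be stated; the two lower numbers simply show that the other substitution patterns on the aniline ring, or the reversed arrangement of compound 3, are read as weaker at the tested concentration.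

Compound 4, `COc1ccc(C(F)(F)F)cc1Nc1cc(NC(=O)Nc2c(Cl)cccc2Cl)ncn1`, keeps the shared core of compound 1 and changes one group: trifluoromethyl in place of methoxy on an aromatic carbon. Within the data shown here, the step from compound 1 to compound 4 in this assay has no measured precedent, and the nearest indication is compound 2, whose 43% shows that an altered substituent on this ring can cost much. A decrease beyond the scatter is expected, though a smaller one than that seen for compound 2; the expected step is a number 23.7 percentage points lower from compound 1 to compound 4 (beyond the scatter). Compound 4 is estimated at 58%, with a range from 32% to 82%.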

Compound 4, a percentage reported as inhibition, at one concentration (the size of the read-out at that concentration, not a potency): 60.1%
Compound 4: middle estimate off by 2.1 percentage points, on the low side, within the range that was stated.
By their numbers in this assay, from the lowest: compounds 3 and 2 (each within the scatter of the next); then compound 4; then compound 1.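

In this assay, within the data shown here, the replacement of methoxy by trifluoromethyl on an aromatic carbon, meta to a large group and para to a methoxy group, gives the first single-place step: a number 21.6 percentage points lower from compound 1 to compound 4 (beyond the scatter). This place on the aniline ring is therefore not indifferent to the group it carries, yet the change does not remove the read-out, since compound 4 still gives 60.1% at the tested concentration. No measurement at hand bears on the reason for this step, so it stands as an observation only.

With a single pair at this place, the compounds shown cannot separate what leaving methoxy contributes from what entering trifluoromethyl contributes, and how a plain hydrogen, a chlorine atom or an amine would read there remains open. As far as these compounds go, the methoxy group that stays unchanged between compound 1 and compound 4 also remains untested by any single-place step, so its share in the read-out cannot be stated.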